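Chlorophenyl attachment point in the amide series

A few compounds are considered here, and "the series" means these few. Any claim that something is new, unique, unknown or untested is made for them only; others in the source may bear on it.

Compound 3 `O=C(Nc1cc(C(F)(F)F)cc(C(F)(F)F)c1)C1CCc2ccccc2N1C(=O)c1ccc(Cl)cc1` gives the lowest number of the three measured in a functional assay on MDA-MB-231 cells (Homo sapiens) for cytotoxicity, read by sulforhodamine B assay, with a stated time of 72 h; a lower number here means a stronger inhibitor of growth, a higher number a weaker inhibitor of growth: compound 3 gives 2000 nM. Compound 1 `O=C(Nc1ccccc1C(F)(F)F)C1CCc2ccccc2N1C(=O)c1ccccc1` gives 5290 nM in this assay, and compound 2 `O=C(Nc1ccccc1)C1CCc2ccccc2N1` gives 108000 nM; both gaps to compound 3 lie beyond the scatter, so compound 3 is the strongest growth inhibitor among the measured compounds. Compound 4 `O=C(Nc1cc(C(F)(F)F)cc(C(F)(F)F)c1)C1CCc2ccccc2N1C(=O)c1cccc(Cl)c1` differs from compound 3 by 3-chlorophenyl in place of 4-chlorophenyl on a carbonyl carbon. Among the measured compounds shown here, no measured pair shows this change, so its effect is unknown; the expectation is a step of no more than modest size, most likely within the scatter or a slight weakening. Compound 4 is expected to give 2600 nM in this assay, with a range of 1000 nM to 7000 nM. The expected step is a 1.3-fold higher number from compound 3 to compound 4 (0.11 log units; within the scatter).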

Compound 4, concentration for 50% growth inhibition: 1190 nM
The estimate for compound 4 lay 2.2-fold (0.34 log units) above the measured number, within the range that was stated.
By their numbers in this assay, from the lowest: compounds 4 and 3 (each within the scatter of the next); then compound 1; then compound 2.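

In this assay, 3-chlorophenyl in place of 4-chlorophenyl on a carbonyl carbon gives a 1.7-fold lower number from compound 3 to compound 4 (0.23 log units; within the scatter), so the two chlorophenyl groups cannot be told apart at this position. Among the compounds shown here, this is the first step that differs in one place, which the earlier compounds could not provide. No supporting data bear on this result.

Open, as far as these compounds go, is how an amine, a carboxylic acid or a longer alkyl chain in place of the chlorophenyl would read in this assay. Also open, from the compounds shown here alone, is what the chlorine itself contributes, since no unsubstituted phenyl partner shares the rest of compound 3 .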